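This account rests on a few compounds, and the source may have more. Where it says the series, first, only, none or still open, it means among the compounds named here.

Compound 1 `C/C(C(=O)NC1CC1)=C(\C)c1ccc(C)cc1` is one of three closely related amides tested in a toxicity assay on the whole organism (strain Icem-CET (SPF Caw)) for cytotoxicity, with Mus musculus as the target (a lower number here means that less compound is needed, a higher number that more compound is needed for the effect), where compound 1 gives 280 mg/kg. Compound 2 `C=CCNC(=O)/C(C)=C(/C)c1ccc(C)cc1` gives 280 mg/kg, and the step of no change at the digits printed from compound 1 to compound 2 (within the scatter) is within the scatter. Compound 3 `C/C(C(=O)NC1CC1)=C(\C)c1ccc(Cl)cc1` gives 170 mg/kg, and the step of a 1.6-fold lower number from compound 1 to compound 3 (0.22 log units; within the scatter) is also within the scatter, so all three numbers sit close together. Compound 4 `C/C(C(=O)NC1CC1)=C(/C)c1ccc(C)cc1` differs from compound 1 only in configuration: the two compounds have the same atoms and bonds and differ only in configuration as drawn: 1 of 1 stereo elements differ; a double bond is drawn Z in compound 1 and E in compound 4. Neither measured step touched the double bond geometry, so none bears directly on this change, and both stayed within the scatter. Compound 4 is therefore expected to show a step of no change at the digits printed from compound 1 to compound 4 (within the scatter). The estimated value for compound 4 is 280 mg/kg, expected to fall between 170 mg/kg and 450 mg/kg.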

Compound 4, dose for half-maximal effect: 110 mg/kg
For compound 4 the middle estimate is 2.5-fold (0.41 log units) above the measured one, outside the stated range (below it).
By their numbers in this assay, from the lowest: compounds 4, 3, 1 and 2 (each within the scatter of the next, the first and the last beyond it).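

In this assay, the geometry of the double bond alone shifts the number: the step is a 2.5-fold lower number from compound 1 to compound 4 (0.41 log units; beyond the scatter), modest, but the only one so far that lies beyond the scatter. The earlier changes, allyl on the amide nitrogen and chloro on the aromatic carbon, both stayed within it. This step can be tied to a single structural difference: the fact that compounds 1 and 4 differ only in the configuration as drawn

As far as these compounds go, whether the same switch in geometry gives a similar step with allyl or chloro in place remains open. So does how a longer chain on the amide nitrogen, or a methoxy group on the aromatic carbon, would behave with either geometry.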